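Replacing the 4-methoxyphenyl group of compound 2

The source may report more compounds than this note shows. Statements on the series, on what has been measured and on what is new or still open speak of the compounds shown alone.

Of the compounds shown here, three have been measured in a functional assay on K562 cells (Homo sapiens) for inhibition, read by trypan blue exclusion, with a stated time of 72 h; a lower number here means a stronger inhibitor, a higher number a weaker inhibitor: compound 1 (`COc1ccc(Nc2ncc3cc(S(=O)(=O)c4ccc(C)cc4)c(=O)n(C)c3n2)cc1`) at (75000 nM), compound 2 (`COc1ccc(Nc2ncc3cc(S(=O)(=O)c4ccc(Cl)cc4)c(=O)n(C)c3n2)cc1`) at (15000 nM) and compound 3 (`COC(=O)Cn1ccc2cc(Nc3ncc4cc(S(=O)(=O)c5ccc(F)cc5F)c(=O)n(C)c4n3)ccc21`) at (5000 nM). Compound 2 therefore holds the middle place, with compound 3 lower and compound 1 higher, both beyond the scatter.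

Among the compounds with values here, the next compound, compound 4 (`Cn1c(=O)c(S(=O)(=O)c2ccc(Cl)cc2)cc2cnc(Nc3cnc4[nH]ccc4c3)nc21`), keeps the chloro-bearing part of compound 2 and changes only one group (a group of 9 heavy atoms (7 carbon, 2 nitrogen; one five-membered aromatic ring with 1 hetero atom, one six-membered aromatic ring with 1 hetero atom) in place of a group of 8 heavy atoms (7 carbon, 1 oxygen; one six-membered aromatic ring of carbon only), on a nitrogen on an aromatic ring). The new group sits on a nitrogen on an aromatic ring, and it has one five-membered and one six-membered aromatic ring.

Within the data shown here, the only measured step (a 5.0-fold lower number from compound 1 to compound 2 (0.70 log units; beyond the scatter)) is a modest one, but it swaps chloro for methyl elsewhere in the molecule and says nothing directly about this change. The nearest guide is compound 3 (5000 nM), which also differs from compound 2 at this nitrogen, though not there alone, so the comparison is loose. A modest fall in the number is therefore expected, although a step within the scatter remains possible.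

For compound 4 the estimated value is (5000 nM), expected to lie between (1000 nM) and (20000 nM). The estimated change is (a 3.0-fold lower number from compound 2 to compound 4 (0.48 log units; beyond the scatter)).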

Compound 4, half-maximal inhibitory concentration: 5000 nM
Compound 4: the middle estimate sits on the measured number at the digits printed, and the stated range covers the measured number.
By their numbers in this assay, from the lowest: compounds 3 and 4 (each within the scatter of the next); then compound 2; then compound 1.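

In this assay, within the data shown here, the step of a 3.0-fold lower number from compound 2 to compound 4 (0.48 log units; beyond the scatter) gives the first reading of a change made at this nitrogen on an aromatic ring alone, with the chloro-bearing part held constant. It shows that the 4-methoxyphenyl group can give way to a group with one five-membered and one six-membered aromatic ring, which carries a hydrogen-bond donor that the departing group lacks, and that the number still falls beyond the scatter. Together with a 5.0-fold lower number from compound 1 to compound 2 (0.70 log units; beyond the scatter), which swaps chloro for methyl on an aromatic carbon, there are now two separate places where a single change moves the number, though no measurement available here accounts for this new step.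

The compounds shown leave open which feature of the new group goes with the step, as its two ring nitrogens, its hydrogen-bond donor and its five-membered ring all enter together. Going by these compounds, how a piperazine or a carboxylic acid attached to this group would read in this assay also remains open, as does whether the same swap would give a similar step with methyl in place of chloro.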